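The source may report more compounds than this note shows. Statements on the series, on what has been measured and on what is new or still open speak of the compounds shown alone.

Compound 1 `COc1ccc(/C=C/C(=O)Nc2cc3ncnc(Nc4ccc(F)c(Cl)c4)c3s2)cc1`: 22700 nM
Compound 2 `O=C(/C=C/c1ccc(O)cc1)Nc1cc2c(Nc3ccc(Cl)c(Cl)c3)ncnc2s1`: 34300 nM

Both numbers come from a functional assay on A549 cells (Homo sapiens) for antiproliferative activity, read by MTT assay, with a stated time of 48 h; a lower number here means a stronger inhibitor, a higher number a weaker inhibitor. In this assay compound 2 and compound 1 sit within the scatter of each other, so compound 2 cannot be set apart from compound 1 on these two numbers alone.

Compound 3 `COc1ccc(/C=C/C(=O)Nc2cc3c(Nc4ccc(Cl)c(Cl)c4)ncnc3s2)cc1` has not been measured yet. It differs from compound 2 in one place: methyl in place of hydrogen on an oxygen on an aromatic ring. Among the measured compounds shown here, the only hint available is compound 1, which already carries 4-methoxyphenyl and differs from compound 3 elsewhere. Nothing here points to a large effect, because compound 1 gives 22700 nM while compound 2 gives 34300 nM. The step is expected to be small, at most slightly toward a lower number: the expected step is a 1.3-fold lower number from compound 2 to compound 3 (0.12 log units; within the scatter). Compound 3 is therefore estimated at 26000 nM, with a range of 11000 nM to 60000 nM.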

Compound 3, half-maximal inhibitory concentration: 3320 nM
Compound 3: the middle estimate sits 7.8-fold (0.89 log units) above what was measured, and the stated range ends above it.
By their numbers in this assay, from the lowest: compound 3; then compounds 1 and 2 (each within the scatter of the next).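

In this assay the change from 4-hydroxyphenyl to 4-methoxyphenyl gives a 10-fold lower number from compound 2 to compound 3 (1.01 log units; beyond the scatter) and so lies well beyond the scatter, although only methyl replaces hydrogen on an oxygen on an aromatic ring. Compound 1 and compound 2 differ in more than one place and could not isolate this position, whereas this pair shows that the group on this oxygen matters on its own while the rest of the molecule stays the same. Nothing available here gives a reason for this step.

Going by these compounds, it remains open whether methyl is special at this oxygen, or whether a longer chain such as ethyl, or an amine in place of the methoxy group, would give a similar number. On these data alone, it is also open whether the same change would give a step of this size in the setting of compound 1.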